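The compounds below may be only part of what the source reports. "The series", "measured", "known", "first", "only" and "open" are said of these compounds alone.

Working notes on the series in a functional assay on NCI-H2122 cells (Homo sapiens) for inhibition, read by microscopy, with a stated time of 10 days; on this read-out higher numbers stand for weaker inhibition and lower numbers for stronger inhibition. Compound 1 `Cn1nc(-c2ccccc2)c2c1OC(N)=C(C#N)C2c1ccccc1` reaches only the assay limit, > 10000 nM, which is a limit rather than a number (the limit of > 10000 nM in this assay, at which 1 of the 3 values shown sits). Compound 2 `Cc1nn(C)c2c1C(c1ccc(C#N)cc1)C(C#N)=C(N)O2` gives 5600 nM in this assay. Compound 3 `Cn1nc(-c2ccccc2)c2c1OC(N)=C(C#N)C2c1ccc(C#N)cc1` gives 5200 nM, the lowest of the two numbers, with compound 2 nearest and within the scatter. The measured steps are an at least 1.9-fold lower number from compound 1 to compound 3 (0.28 log units; that floor lies within the scatter) and a 1.1-fold lower number from compound 2 to compound 3 (0.03 log units; within the scatter). Compound 4 `Cn1nc(-c2ccccc2)c2c1OC(N)=C(C#N)C2c1cccnc1` differs from compound 3 by pyridin-3-yl in place of 4-cyanophenyl on a saturated ring carbon. Within the data shown here, only the step from compound 1 to compound 3 bears on it, since compound 4 again lacks the cyano; a rise in this assay is therefore expected. For compound 4 the expected value is 9000 nM, between 4000 nM and 20000 nM. The step expected is a 1.7-fold higher number from compound 3 to compound 4 (0.24 log units; within the scatter).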

Compound 4, half-maximal inhibitory concentration: > 10000 nM
Compound 4 was reported as a limit (the forecaster's own chance of this, stated with the estimate: 40%); middle value at least 1.1-fold (0.04 log units) from the limit.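

In this assay, compound 4 stands at a limit, not a number: the limit of > 10000 nM in this assay, at which 2 of the 4 values shown sit. Pyridin-3-yl in place of 4-cyanophenyl on this saturated ring carbon gives an at least 1.9-fold higher number from compound 3 to compound 4 (0.28 log units; that floor lies within the scatter), so among the three groups shown on the shared core, only 4-cyanophenyl gives a number. The step between the two compounds at the limit cannot be read, so phenyl and pyridin-3-yl cannot be ranked. Open, going by these compounds, is whether the nitrile itself matters, since the floor of the step does not clear the scatter. Also open, on these data alone, is how an amine or a carboxylic acid in place of the cyano of 4-cyanophenyl would read.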